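A few compounds are considered here, and "the series" means these few. Any claim that something is new, unique, unknown or untested is made for them only; others in the source may bear on it.

Working notes on the series. In a functional assay on SH-SY5Y cells (Homo sapiens) for cytotoxicity, read by MTT assay, with a stated time of 72 h (on this read-out higher numbers stand for weaker inhibition and lower numbers for stronger inhibition), compound 1 `O=C1c2c[n+]([O-])c3ccccc3c2C(=O)c2c1c1ccccc1n2Cc1cn(C[C@H](O)CO)nn1` reads > 1000 nM, and this is a limit of the assay, not a number. For the measured compounds named here, compound 2 `CN(C)CCCCn1c2c(c3ccccc31)C(=O)c1c[n+]([O-])c3ccccc3c1C2=O` gives 250 nM, the only actual number so far, which makes it the reference point for the next comparison.

Compound 3 `O=C1c2c[n+]([O-])c3ccccc3c2C(=O)c2c1c1ccccc1n2CCCN1CCC(O)CC1` differs from compound 2 as follows: 4-hydroxypiperidin-1-yl in place of (dimethylamino)methyl on a saturated chain carbon, three bonds along the chain from an aromatic nitrogen. This places 4-hydroxypiperidin-1-yl in place of (dimethylamino)methyl on a saturated chain carbon, three bonds along the chain from an aromatic nitrogen.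

Going by the values given here, one measured step bears on this change, and only indirectly: an at least 4.0-fold lower number from compound 1 to compound 2 (0.60 log units; beyond the scatter). It involves a different exchange on the same side chain, but shows that such an exchange can move this read-out beyond the scatter. Among the compounds with values here, compound 1, the only measured compound with hydroxyl groups on its side chain, stands at the limit of > 1000 nM. A small move toward a higher number in this assay is therefore expected, smaller than the measured step.

The estimate means a 1.5-fold higher number from compound 2 to compound 3 (0.18 log units; within the scatter), an expected step that may not clear the scatter. For compound 3 the expected value is 380 nM, with an estimated range of 130 nM to 1000 nM.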

Compound 3, half-maximal inhibitory concentration: 130 nM
Estimate against measurement, compound 3: 2.9-fold (0.47 log units) above, within the range that was stated.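

In this assay, the change to the ring-bearing side chain gives a 1.9-fold lower number from compound 2 to compound 3 (0.28 log units; within the scatter), so 4-hydroxypiperidin-1-yl in place of (dimethylamino)methyl, on a saturated chain carbon, three bonds along the chain from an aromatic nitrogen, does not separate the two readings. The hydroxyl-bearing compound 1 had left open whether any hydroxyl on the side chain goes with a weak reading, but the second new step, an at least 7.6-fold lower number from compound 1 to compound 3 (0.88 log units; beyond the scatter), shows that a side chain with a hydroxyl can still read well clear of the limit, so no such link holds across the compounds shown. The reading for compound 1 remains a limit and not a number, so that step has only a lower bound on its size: the limit of > 1000 nM in this assay, at which 1 of the 3 values shown sits.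

Still open, as far as these compounds go, is whether the ring or its hydroxyl sets the reading of compound 3, a question that a plain piperidin-1-yl or a morpholin-4-yl at the same place would address. Also open, from the compounds shown here alone, is how a shorter or longer chain carrying 4-hydroxypiperidin-1-yl would read, and how a carboxylic acid at the chain end would read.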